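Nitro for Nitrile, Carried onto a Second Core

This account rests on a few compounds, and the source may have more. Where it says the series, first, only, none or still open, it means among the compounds named here.

Two pairs of amides share a single change at the carbonyl carbon. Compound 1 `O=C(Nc1cc(-c2ccccc2)nn1-c1ccccc1Br)c1ccc([N+](=O)[O-])cc1` and compound 2 `N#Cc1cccc(C(=O)Nc2cc(-c3ccccc3)nn2-c2ccccc2Br)c1` are built on one core; compound 3 `N#Cc1cccc(C(=O)Nc2cn(-c3ccccc3)nc2-c2ccccc2)c1` and compound 4 `O=C(Nc1cn(-c2ccccc2)nc1-c1ccccc1)c1ccc([N+](=O)[O-])cc1` rest on a second core, and the difference between the two cores is not broken down here.

In an assay on HEK293 cells for displacement of a labelled ligand from metabotropic glutamate receptor 5 (Rattus norvegicus) (on this read-out higher numbers stand for weaker inhibition and lower numbers for stronger inhibition), compound 1 gives 120 nM. In the same measurement compound 2 gives 230 nM. The step between them, a 1.9-fold lower number from compound 2 to compound 1 (0.28 log units; within the scatter), corresponds to 4-nitrophenyl in place of 3-cyanophenyl on a carbonyl carbon. For compound 3 the this assay reports only a limit, > 10000 nM, and not a number. That entry sits at the limit of > 10000 nM in this assay, at which 1 of the 3 values shown sits.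

Compound 4 carries the identical change onto the second core: 4-nitrophenyl in place of 3-cyanophenyl on a carbonyl carbon. The place is described in the same words for both pairs, so this is the same change, not merely the same kind. Its one measured occurrence shifted the read-out only within the usual scatter, which gives no reason to expect that a compound already at the limit would be pulled into the measurable range.

For compound 4 the expected step that the limit leaves unreadable from compound 3 to compound 4 is small because a 1.9-fold lower number from compound 2 to compound 1 (0.28 log units; within the scatter) stayed within the scatter. Compound 4 is therefore estimated at 15000 nM in the this assay, with a likely range from 5000 nM to 50000 nM, and most probably the assay will again report only a limit.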

Compound 4, inhibition constant: > 10000 nM
Compound 4 was reported as a limit; the forecaster's own chance of this, stated with the estimate: 75%; the middle value does not contradict the limit.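

Compound 3 and compound 4 are both reported in this assay only as limits and not as numbers, so no step can be read between them: the limit of > 10000 nM in this assay, at which 2 of the 4 values shown sit.

The compounds shown leave open whether 4-nitrophenyl in place of 3-cyanophenyl on a carbonyl carbon acts on the core of compound 3 as it does on the core of compound 1.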